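Replacing 2,2,2-trifluoroethyl with 1-(tert-butyl)azetidin-3-yl on the oxygen

The compounds below may be only part of what the source reports. "The series", "measured", "known", "first", "only" and "open" are said of these compounds alone.

- compound 1 `COc1cc(-c2nnc3c(OC4COC4)cc(-c4ccc5[nH]ccc5c4)cn23)cc(OC)c1OC` gives 2470 nM in a functional assay on MCF7 cells (Homo sapiens) for antiproliferative activity, read by MTT assay, with a stated time of 48 h; on this read-out lower numbers stand for stronger inhibition and higher numbers for weaker inhibition
- compound 2 `COc1cc(-c2nnc3c(OCC(F)(F)F)cc(-c4ccc5[nH]ccc5c4)cn23)cc(OC)c1OC` gives 608 nM in this assay

Compound 2 holds the lower of the two numbers. Going by the values given here, replacing oxetan-3-yl by 2,2,2-trifluoroethyl on the oxygen gave a 4.1-fold lower number from compound 1 to compound 2 (0.61 log units; beyond the scatter) and is the only measured step. Compound 3 `COc1cc(-c2nnc3c(OC4CN(C(C)(C)C)C4)cc(-c4ccc5[nH]ccc5c4)cn23)cc(OC)c1OC` is changed at that same oxygen on an aromatic ring, with 1-(tert-butyl)azetidin-3-yl in place of 2,2,2-trifluoroethyl on an oxygen on an aromatic ring as the counted difference. In words, 1-(tert-butyl)azetidin-3-yl takes the place of 2,2,2-trifluoroethyl. The entering group has a four-membered non-aromatic ring, as does the oxetan-3-yl of compound 1, whereas the leaving group has no ring. Among the compounds with values here, two compounds establish no trend, and no measured compound carries the tert-butyl azetidine. The closest guide is compound 1 at 2470 nM in this assay as the ring-bearing comparison, so a higher number than that of compound 2 is expected, by a step similar to or smaller than the measured one. The expected step is a 2.5-fold higher number from compound 2 to compound 3 (0.39 log units; beyond the scatter) with wide uncertainty. The estimated value for compound 3 is 1500 nM within an expected range of 400 nM to 5500 nM as a working figure.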

Compound 3, half-maximal inhibitory concentration: > 10000 nM
Compound 3 ended at the assay's limit; the forecaster's own chance of this, stated with the estimate: 4%; middle value at least 6.6-fold (0.82 log units) from the limit.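

In this assay the entry for compound 3 is a limit of the assay and not a number: the limit of > 10000 nM in this assay, at which 1 of the 3 values shown sits. Placing 1-(tert-butyl)azetidin-3-yl on the oxygen on an aromatic ring gives an at least 16-fold higher number from compound 2 to compound 3 (1.21 log units; beyond the scatter) and so shows that this position can move the read-out by a large step, not only the modest one seen earlier. Against the oxetan-3-yl group the same change gives an at least 4.0-fold higher number from compound 1 to compound 3 (0.60 log units; beyond the scatter) and shows that a four-membered non-aromatic ring on this oxygen does not alone set the number, since the two ring-bearing compounds lie beyond the scatter of each other.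

The three compounds do not tell whether the loss follows the ring nitrogen, the tert-butyl group or the two together. An azetidin-3-yl group without the tert-butyl, a 1-methylazetidin-3-yl group and a plain ethyl group on the same oxygen would each separate these parts, and a longer fluorinated chain would show whether anything on this oxygen reads lower than compound 2 does.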